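The source may hold more compounds than are shown below. What is called first, only, known or untested is meant among the compounds shown, and "the series" means these compounds.

Measured so far:
compound 1, `COc1nc2ccc(Br)cc2cc1C(c1ccccc1)n1cc(-c2ccc(Br)cc2)nn1`, gives 13.4% in an ADME assay on SK-OV-3 cells (Homo sapiens) for cytotoxicity, read by sulforhodamine B assay, with a stated time of 48 h, tested at 10 uM; on this read-out lower numbers stand for less inhibition and higher numbers for more inhibition at the one concentration tested (going by the name of the read-out);
compound 2, `CCOC(=O)c1cn(C(c2ccccc2)c2cc3cc(Br)ccc3nc2OC)nn1`, gives 2.01%;
compound 3, `CCCCCc1cn(C(c2ccccc2)c2cc3cc(Br)ccc3nc2OC)nn1`, gives 10.5%.

All three numbers are low, and compound 3 sits second highest of the three: its nearest neighbour is compound 1, whose number lies a number 2.9 percentage points lower from compound 1 to compound 3 (within the scatter), while compound 2 lies further off, a number 8.5 percentage points higher from compound 2 to compound 3 (within the scatter). Only the move to compound 2 stands out, a number 11.4 percentage points lower from compound 1 to compound 2 (beyond the scatter), so the exchange of an aryl ring for a pentyl chain did not shift the read-out beyond the scatter.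

Compound 4, `COc1nc2ccc(Br)cc2cc1C(c1ccccc1)n1cc(-c2ccccc2C(F)(F)F)nn1`, has not yet been measured. It carries 2-(trifluoromethyl)phenyl in place of pentyl on an aromatic carbon. Among the measured compounds shown here, the step that bears on it most directly is the one between compound 1 and compound 3, where a 4-bromophenyl and a pentyl gave numbers within the scatter of each other. Since the group entering in compound 4 is again a phenyl ring, its number is expected to land near those of compound 1 and compound 3, with no step beyond the scatter: a number 1.5 percentage points higher from compound 3 to compound 4 (within the scatter) is the expected change. Compound 4 is therefore estimated at 12%, within the range 2% to 25%.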

Compound 4, a percentage reported as inhibition, at one concentration (the size of the read-out at that concentration, not a potency): 9.55%
Compound 4: middle estimate off by 2.5 percentage points, on the high side, and the stated range covers the measured number.
By their numbers in this assay, from the lowest: compounds 2, 4, 3 and 1 (each within the scatter of the next, the first and the last beyond it).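

In (this assay), the 2-(trifluoromethyl)phenyl group on this aromatic carbon of the five-membered ring cannot be told apart from pentyl (a number 1 percentage points lower from compound 3 to compound 4 (within the scatter)) or from 4-bromophenyl (a number 3.9 percentage points lower from compound 1 to compound 4 (within the scatter)), so a second aryl group with a different substituent gives the same picture as the first aryl group and the chain. Among the compounds shown here, the comparison with ethoxycarbonyl is less sharp (a number 7.5 percentage points higher from compound 2 to compound 4 (within the scatter)), which means that the separation of the ester from the aryl groups holds for 4-bromophenyl but not for 2-(trifluoromethyl)phenyl, and the one step beyond the scatter rests on a single pair of compounds. No measurement offered here accounts for these numbers.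

The compounds shown leave open whether an amine, a carboxylic acid in place of the ethoxycarbonyl, or a chain longer than pentyl at this position would give a number clearly apart from this low cluster. As far as these compounds go, they also differ only at this one position, so what a change elsewhere on the shared core, such as replacing the methoxy group or the bromine, would do remains open.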